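Working notes: compound 4 set against compounds 1 to 3

The source may hold more compounds than are shown below. What is called first, only, known or untested is meant among the compounds shown, and "the series" means these compounds.

Measured so far:
compound 1 `CCCCNC(=O)NS(=O)(=O)c1ccc(-n2nc(-c3ccc(C)cc3)ccc2=O)cc1` gives 86.6% in a functional assay on the whole organism (blood, strain Wistar albino) for inhibition, with Rattus norvegicus as the target, read by colorimetric assay, with stated times of 15 min and 90 min, at a dose of 20 mg/kg by the oral route; a lower number here means less inhibition, a higher number more inhibition at the dose given (going by the name of the read-out)
compound 2 `Cc1ccc(-c2ccc(=O)n(-c3ccc(S(=O)(=O)NC(=O)NC4CCCCC4)cc3)n2)cc1` gives 79.9% in this assay
compound 3 `Cc1ccc(-c2ccc(=O)n(-c3ccc(S(=O)(=O)NC(=O)NCc4ccccc4)cc3)n2)cc1` gives 64.9% in this assay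

Compound 2 stands second highest of the three numbers. Its nearest neighbour is compound 1: a number 6.7 percentage points lower from compound 1 to compound 2 (within the scatter), a gap within the scatter, so no order between compound 1 and compound 2 is claimed. Compound 3 lies further off: a number 15 percentage points lower from compound 2 to compound 3 (beyond the scatter), beyond the scatter, as is a number 21.7 percentage points lower from compound 1 to compound 3 (beyond the scatter). All three measured steps alter the group on the amide-type nitrogen; none touches the aromatic carbon at which compound 4 `Cc1cc(-c2ccc(=O)n(-c3ccc(S(=O)(=O)NC(=O)NC4CCCCC4)cc3)n2)ccc1Cl` differs from compound 2: 4-chloro-3-methylphenyl in place of 4-methylphenyl on an aromatic carbon. Among the measured compounds shown here, no measured step therefore bears on this change, and the series gives no ground for expecting a shift beyond the scatter in either direction in this assay. Compound 4 is expected to give 78%, with a range of 62% to 90%. For the measured compounds named here, the expected step of a number 1.9 percentage points lower from compound 2 to compound 4 (within the scatter) is estimated to fall within the scatter, the range kept wide since no measured step informs it.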

Compound 4, a percentage reported as inhibition, in the whole organism at one dose (the size of the read-out at that dose, not a potency): 62.1%
Beside the measured number, compound 4's estimate is 15.9 percentage points above it, and the stated range covers the measured number.
By their numbers in this assay, from the lowest: compounds 4 and 3 (each within the scatter of the next); then compounds 2 and 1 (each within the scatter of the next).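

Among the compounds shown here, compound 4 gives the first step away from the group on the amide-type nitrogen: in this assay, 4-chloro-3-methylphenyl in place of 4-methylphenyl gives a number 17.8 percentage points lower from compound 2 to compound 4 (beyond the scatter). The aryl group on the shared core therefore also moves this read-out beyond the scatter, with the cyclohexyl group held constant, and does so to an extent not shown by the earlier compounds. Nothing at hand accounts for this step.

The step combines a chloro group with a relocated methyl group, so 4-chlorophenyl and 3-methylphenyl at this position would be needed to separate the two parts. As far as these compounds go, it also remains open whether the step carries over to compounds with butyl or benzyl in place of cyclohexyl on the amide-type nitrogen.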